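A few compounds are considered here, and "the series" means these few. Any claim that something is new, unique, unknown or untested is made for them only; others in the source may bear on it.

Measured compounds:
- compound 1, `CN(C)CCn1cnnc1-c1cc(Oc2ccc(NC(=O)N/N=C/c3c[nH]c4ccccc34)cc2F)ccn1` — 790 nM in a functional assay on MKN-45 cells (Homo sapiens) for cytotoxicity, read by MTT assay, with a stated time of 72 h; a higher number here means a weaker inhibitor, a lower number a stronger inhibitor
- compound 2, `COc1ccc(OC)c(/C=N/NC(=O)Nc2ccc(Oc3ccnc(-c4nncn4CCN(C)C)c3)c(F)c2)c1` — 1510 nM in this assay
- compound 3, `COc1ccc(/C=N/NC(=O)Nc2ccc(Oc3ccnc(-c4nncn4CCN(C)C)c3)c(F)c2)c(OC)c1` — 1680 nM in this assay

Compound 3 gives the highest of the three numbers; its distance from compound 1 is a 2.1-fold higher number from compound 1 to compound 3 (0.33 log units; beyond the scatter), whereas compound 2 and compound 3 sit within the scatter of each other, the step being a 1.1-fold higher number from compound 2 to compound 3 (0.05 log units; within the scatter). Compound 4, `COc1ccc(/C=N/NC(=O)Nc2ccc(Oc3ccnc(-c4nncn4CCN(C)C)c3)c(F)c2)c(OC)c1OC`, differs from compound 3 in one place: methoxy in place of hydrogen on an aromatic carbon. Within the data shown here, the one measured step that touches the same region is a 1.1-fold higher number from compound 2 to compound 3 (0.05 log units; within the scatter), where shifting a methoxy group from one aromatic carbon to another left the read-out essentially unchanged. The larger swaps of the whole ring, a 1.9-fold higher number from compound 1 to compound 2 (0.28 log units; within the scatter) and a 2.1-fold higher number from compound 1 to compound 3 (0.33 log units; beyond the scatter), moved the numbers only a little. Among the measured compounds shown here, no measured pair shows what adding a third methoxy group does. The expectation is therefore a step of a 1.0-fold higher number from compound 3 to compound 4 (0.01 log units; within the scatter), meaning none beyond the scatter. Compound 4 is estimated at 1700 nM, with a range from 800 nM to 3600 nM.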

Compound 4, half-maximal inhibitory concentration: 2020 nM
For compound 4 the middle estimate is 1.2-fold (0.07 log units) below the measured one, and the stated range covers the measured number.
By their numbers in this assay, from the lowest: compounds 1, 2, 3 and 4 (each within the scatter of the next, the first and the last beyond it).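

Adding a third methoxy group at this position, ortho to two methoxy groups, turns the 2,4-dimethoxyphenyl ring into a 2,3,4-trimethoxyphenyl ring and gives a step within the scatter in this assay (a 1.2-fold higher number from compound 3 to compound 4 (0.08 log units; within the scatter)), which is a direct reading of an added group, where the earlier pairs only moved a methoxy group or swapped a whole ring. The 2,3,4-trimethoxyphenyl ring also stays within the scatter of the 2,5-dimethoxyphenyl ring (a 1.3-fold higher number from compound 2 to compound 4 (0.13 log units; within the scatter)), while the step from the 1H-indol-3-yl group goes beyond it (a 2.6-fold higher number from compound 1 to compound 4 (0.41 log units; beyond the scatter)). No measurement here gives a reason for these readings.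

The compounds shown leave open what a hydroxyl group, an amine or a carboxylic acid would do at this same position. They also leave open whether a longer chain, such as ethoxy, would read like methoxy there.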